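Cytotoxicity notes: acetyl in place of benzylimidazole arm

A few compounds are considered here, and "the series" means these few. Any claim that something is new, unique, unknown or untested is made for them only; others in the source may bear on it.

The series is followed in a toxicity assay on NIH3T3 cells (Mus musculus) for cytotoxicity, read by resazurin assay; a higher number here means that more compound is needed for the effect, a lower number that less compound is needed. Compound 1 `c1ccc(-c2ccc(Cn3cncc3CNc3ccc(-c4onc5ccccc45)c(-c4ccccc4)c3)cc2)cc1` gives in this assay only a limit, > 10000 nM. Compound 2 `COC(=O)c1ccc(NCc2cncn2Cc2cccc(Br)c2)cc1-c1ccccc1` likewise gives in this assay a limit, > 10000 nM. For compound 3 `COC(=O)c1ccc(NCc2cncn2Cc2cccc(-c3ccccc3)c2)cc1-c1ccccc1` this assay shows "not determined" (no result reported), that is, no result was reported. Compound 1 thus stands at the limit of > 10000 nM in this assay, at which 2 of the 3 values shown sit, and no single number exists anywhere in the set to place it above or below another compound. Compound 4 `CC(=O)c1ccc(NCc2cncn2Cc2ccc(-c3ccccc3)cc2)cc1-c1ccccc1` differs from compound 1 by a group of 3 heavy atoms (2 carbon, 1 oxygen; no ring) in place of a group of 9 heavy atoms (7 carbon, 1 nitrogen, 1 oxygen; one five-membered aromatic ring with 2 hetero atoms, one six-membered aromatic ring of carbon only), on an aromatic carbon. Going by the values given here, no measured pair isolates this change, so no step is on record for it.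

For compound 4 the expectation is that this assay again reports a limit rather than a number, because compound 1 already sits at the limit of > 10000 nM in this assay, at which 2 of the 3 values shown sit. The expected step is a step that the limit leaves unreadable from compound 1 to compound 4, nothing beyond the usual scatter in either direction. Compound 4 is estimated at 15000 nM, with a range from 7000 nM to 40000 nM.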

Compound 4, half-maximal effective concentration: > 10000 nM
Compound 4 was reported as a limit; the forecaster's own chance of this, stated with the estimate: 75%; the middle value is on the limit's open side.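

Compound 1 and compound 4 both stand as limits in this assay, so no step can be read between them: the limit of > 10000 nM in this assay, at which 3 of the 4 values shown sit.

Whether acetyl in that place shifts cytotoxicity in either direction stays open, and no compound shown has a single number in this assay.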